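Swapping a Benzylamine for a Piperidine on a Pyridine Core

The compounds below may be only part of what the source reports. "The series", "measured", "known", "first", "only" and "open" are said of these compounds alone.

Measured compounds:
- Compound 1 `CC(C(=O)NCc1ccc(C(F)(F)F)nc1NCc1ccc(Cl)cc1)c1ccc(NS(C)(=O)=O)c(F)c1`: 414 nM
- Compound 2 `C[C@H](C(=O)NCc1ccc(C(F)(F)F)nc1N1CCC[C@H]1C(=O)N(C)C)c1ccc(NS(C)(=O)=O)c(F)c1`: "not active" (no number reported)
- Compound 3 `C[C@H](C(=O)NCc1ccc(C(F)(F)F)nc1N1CC[C@@H](OCc2ccccc2)C1)c1ccc(NS(C)(=O)=O)c(F)c1`: 50 nM

All three share one core and differ only in the group attached to the ring carbon next to the ring nitrogen. In a functional assay on CHO-K1 cells for antagonist activity at transient receptor potential cation channel subfamily V member 1 (Homo sapiens), read by FLIPR (a higher number here means a weaker inhibitor, a lower number a stronger inhibitor), compound 1 gives 414 nM. Of the two compounds with a number, compound 1 stands at the higher end: compound 3, carrying a benzyloxy-substituted pyrrolidine, gives 50 nM, a gap beyond the scatter. Compound 2, with a dimethylamide-bearing pyrrolidine, is reported as "not active" (no number reported) with no number.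

Compound 4 `CC(C(=O)NCc1ccc(C(F)(F)F)nc1N1CCC(C(F)(F)F)CC1)c1ccc(NS(C)(=O)=O)c(F)c1` is the next step from compound 1. The change is 4-(trifluoromethyl)piperidin-1-yl in place of (4-chlorobenzyl)amino on an aromatic carbon. Like compound 3, compound 4 carries a saturated nitrogen ring on that carbon rather than an aminomethyl link to an aromatic ring; unlike compound 2, its ring bears a trifluoromethyl group rather than an amide. For the measured compounds named here, with only two numbers to go on, the expected step for compound 4 is a moderate move toward stronger inhibition, a 2.8-fold lower number from compound 1 to compound 4 (0.44 log units; beyond the scatter), possibly beyond the scatter but not as far as compound 3. The estimate for compound 4 in this assay is therefore 150 nM, within a range from 30 nM to 700 nM.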

Compound 4, half-maximal inhibitory concentration: 31 nM
Beside the measured number, compound 4's estimate is 4.8-fold (0.68 log units) above it, within the range that was stated.
By their numbers in this assay, from the lowest: compounds 4 and 3 (each within the scatter of the next); then compound 1.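

In this assay, the step from a secondary amine linker to a ring nitrogen bonded directly to this aromatic carbon is large: a 13-fold lower number from compound 1 to compound 4 (1.13 log units; beyond the scatter). Activity at this place therefore does not depend on the hydrogen-bond donor or the aromatic ring of (4-chlorobenzyl)amino, since 4-(trifluoromethyl)piperidin-1-yl has neither and still gives the stronger inhibitor. Compound 4 and compound 3 lie within the scatter of each other, which suggests that more than one saturated nitrogen ring can work here, although compound 2, also with such a ring, goes against this with its "not active" result, and nothing available explains any of these differences.

As far as these compounds go, what remains open is whether the step comes from the ring itself or from the trifluoromethyl group it carries; a plain piperidin-1-yl group, or a piperidine with a methyl or a hydroxyl group in place of trifluoromethyl, would separate the two. It is also unclear whether compound 2 loses activity through its dimethylamide, which a simple methyl ester or a methyl ether at the same ring carbon could help test.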